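Trimming the Dichlorophenyl Amide: Phenyl in Compound 4

A few compounds are considered here, and "the series" means these few. Any claim that something is new, unique, unknown or untested is made for them only; others in the source may bear on it.

Among the compounds with values here, compound 3 `O=C(Nc1ccc(Cl)c(-c2nnc3c(Cl)cccn23)c1)c1ccc(Cl)cc1Cl` is the only member of this small set with a numerical result: in a functional assay on MDA-MB-468 cells (Homo sapiens) for antiproliferative activity, read by MTT assay, with a stated time of 72 h (on this read-out lower numbers stand for stronger inhibition and higher numbers for weaker inhibition), compound 3 gives 21600 nM. Compound 1 `O=C(Nc1ccc(Cl)c(-c2nnc3c(Cl)cccn23)c1)c1cccnc1` reaches only a limit in this assay, where compound 1 gives > 100000 nM. Compound 2 `CS(=O)(=O)c1ccc(C(=O)Nc2ccc(Cl)c(-c3nnc4c(Cl)cccn34)c2)cc1` likewise stops at a limit, and in this assay compound 2 gives > 100000 nM. The step from compound 1 to compound 3 is therefore readable only as an at least 4.6-fold lower number from compound 1 to compound 3 (0.66 log units; beyond the scatter), the step from compound 2 to compound 3 as an at least 4.6-fold lower number from compound 2 to compound 3 (0.66 log units; beyond the scatter), while the step from compound 1 to compound 2 is a step that the two limits leave unreadable from compound 1 to compound 2. Both readable steps show the number falling away from the limit of > 100000 nM in this assay, at which 2 of the 3 values shown sit, when 2,4-dichlorophenyl enters on the carbonyl carbon.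

Compound 4 `O=C(Nc1ccc(Cl)c(-c2nnc3c(Cl)cccn23)c1)c1ccccc1` has not been measured. It differs from compound 3 by phenyl in place of 2,4-dichlorophenyl on a carbonyl carbon. Within the data shown here, no measured step removes the chlorine substituents while keeping the phenyl ring. Because an at least 4.6-fold lower number from compound 1 to compound 3 (0.66 log units; beyond the scatter) and an at least 4.6-fold lower number from compound 2 to compound 3 (0.66 log units; beyond the scatter) both accompany the entry of 2,4-dichlorophenyl, its loss in compound 4 is expected to move the number upward in this assay, by about a 2.8-fold higher number from compound 3 to compound 4 (0.44 log units; beyond the scatter), with a real chance that only a limit is reported. The estimate for compound 4 in this assay is 60000 nM, expected to lie between 20000 nM and 150000 nM.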

Compound 4, half-maximal inhibitory concentration: > 100000 nM
Compound 4: no number, only a limit; the forecaster's own chance of this, stated with the estimate: 40%; middle value at least 1.6-fold (0.22 log units) away from the limit.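

In this assay, phenyl in place of 2,4-dichlorophenyl on a carbonyl carbon gives an at least 4.6-fold higher number from compound 3 to compound 4 (0.66 log units; beyond the scatter), a change that keeps the six-membered aromatic ring of carbon and takes away only its two chlorine atoms. The earlier readable steps replaced pyridin-3-yl or 4-(methylsulfonyl)phenyl, so they could not separate the chlorine atoms from the rest of the group, whereas this step shows that the unsubstituted phenyl ring does not by itself give a measurable result, and compound 4 stops at a limit, as the set now shows: the limit of > 100000 nM in this assay, at which 3 of the 4 values shown sit. The steps from compound 1 and from compound 2 to compound 4 cannot be read, since each joins two limits, so pyridin-3-yl, 4-(methylsulfonyl)phenyl and phenyl cannot be ranked against one another.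

The compounds shown leave open whether both chlorine atoms are needed, since no phenyl ring carrying a single chlorine appears among them. They also leave open whether fluorine, bromine, methyl or methoxy on the ring would serve in the same way as chlorine, or whether an amine or a carboxylic acid there would bring the number down further.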